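Halogen swap on the aryl group at the assay limit

A few compounds are considered here, and "the series" means these few. Any claim that something is new, unique, unknown or untested is made for them only; others in the source may bear on it.

Measured so far in a functional assay on A549 cells (Homo sapiens) for antiproliferative activity, read by MTT assay, with a stated time of 48 h; on this read-out lower numbers stand for stronger inhibition and higher numbers for weaker inhibition
compound 1 `COc1ccc(-c2nc3cccc(-c4cc(OC)c(OC)c(OC)c4)c3o2)cc1` gives 2200 nM
compound 2 `COc1cc(-c2cccc3nc(-c4ccc(Br)cc4)oc23)cc(OC)c1OC` gives > 25000 nM (a limit of the assay, not a number)

Compound 2 stands at the limit of > 25000 nM in this assay, at which 1 of the 2 values shown sits, and so has no number of its own. Compound 3 (`COc1cc(-c2cccc3nc(-c4cccc(Cl)c4)oc23)cc(OC)c1OC`) differs from it in one place (3-chlorophenyl in place of 4-bromophenyl on an aromatic carbon): 3-chlorophenyl in place of 4-bromophenyl on an aromatic carbon. Going by the values given here, one measured step bears on this, bromo in place of methoxy on an aromatic carbon, and it shows an at least 11-fold higher number from compound 1 to compound 2 (1.05 log units; beyond the scatter) as a large change. That step exchanges other groups, so it gives no direct size for the present swap. Compound 3 also lacks the methoxy of compound 1, so it is expected to stay near the limit, with only a modest move towards lower numbers in this assay and a real chance of another limit. The expected move is an at least 1.6-fold lower number from compound 2 to compound 3 (0.22 log units; that floor lies within the scatter) at most. For compound 3 the estimated value is 15000 nM (expected range 4000 nM to 50000 nM).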

Compound 3, half-maximal inhibitory concentration: > 25000 nM
Compound 3: no number, only a limit; the forecaster's own chance of this, stated with the estimate: 45%; at least 1.6-fold (0.22 log units) between middle value and limit.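

In this assay, 3-chlorophenyl in place of 4-methoxyphenyl on this aromatic carbon gives an at least 11-fold higher number from compound 1 to compound 3 (1.05 log units; beyond the scatter), so the large loss is not confined to 4-bromophenyl. Among the three compounds, only compound 1, with 4-methoxyphenyl, gives a number, while both halogen-bearing aryl groups end at the limit. The swap from 4-bromophenyl to 3-chlorophenyl itself cannot be read, because compound 2 and compound 3 both stand at the limit: the limit of > 25000 nM in this assay, at which 2 of the 3 values shown sit.

Still open, as far as these compounds go, is how far compound 2 and compound 3 lie from each other, and whether halogen identity or ring placement matters at all. From the compounds shown here alone, it is also open whether the number of compound 1 is specific to methoxy or would persist with a hydroxyl or dimethylamino group on the same phenyl ring.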